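This account rests on a few compounds, and the source may have more. Where it says the series, first, only, none or still open, it means among the compounds named here.

Measured compounds in an assay on HEK293 cells for displacement of a labelled ligand from NPC1-like intracellular cholesterol transporter 1 (Homo sapiens); a higher number here means a weaker inhibitor, a lower number a stronger inhibitor:
Compound 1 `CC(C)(C)c1ccc(C(=O)N2CCC3(CC2)C(=O)N(CC(=O)NCCC(=O)O)CN3c2ccccc2)cc1` gives 11400 nM.
Compound 2 `CC(C)(C)OC(=O)NCCCCNC(=O)CN1CN(c2ccccc2)C2(CCN(C(=O)c3ccc(C(C)(C)C)cc3)CC2)C1=O` gives "not determined" (no result reported) in this assay, so no number is available for it.
Compound 3 `CC(C)(C)c1ccc(C(=O)N2CCC3(CC2)C(=O)N(CC(=O)NCCCN)CN3c2ccccc2)cc1` gives 4200 nM.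

Among the compounds with values here, compound 3 holds the lower of the two numbers in this assay; its only neighbour with a number is compound 1, and a 2.7-fold lower number from compound 1 to compound 3 (0.43 log units; beyond the scatter). That step carries aminomethyl in place of carboxy at the chain end.

Compound 4 `CC(C)(C)c1ccc(C(=O)N2CCC3(CC2)C(=O)N(CC(=O)NCCCCO)CN3c2ccccc2)cc1` is the next variant on the same core. The change from compound 3 is hydroxymethyl in place of amino on a saturated chain carbon, three bonds along the chain from an amide-type nitrogen. Within the data shown here, only one measured step touches this chain end, and it concerns a different pair of groups, so it bears on the change only loosely. The end groups swapped here are of similar size and match in counted donors and acceptors. Compound 4 is therefore expected to sit near compound 3, with an estimated step of a 1.4-fold higher number from compound 3 to compound 4 (0.15 log units; within the scatter), within the scatter. The estimate for compound 4 in this assay is 6000 nM, ranging from 2500 nM to 15000 nM.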

Compound 4, half-maximal inhibitory concentration: 19200 nM
Estimate against measurement, compound 4: 3.2-fold (0.51 log units) below, and the stated range ends below it.
By their numbers in this assay, from the lowest: compound 3; then compounds 1 and 4 (each within the scatter of the next).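

In this assay the swap of 3-aminopropyl for 4-hydroxybutyl gives a 4.6-fold higher number from compound 3 to compound 4 (0.66 log units; beyond the scatter) at this chain end, even though the two groups match in counted donors and acceptors, so those counts do not settle the number here. Set against the carboxy end, the hydroxyl end gives a 1.7-fold higher number from compound 1 to compound 4 (0.23 log units; within the scatter) and so leaves the amine-ended compound 3 alone at the low end of these three numbers. Nothing measured here explains this result.

From the compounds shown here alone, it stays open whether the amine or the chain length matters more. A 3-hydroxypropyl end or a 4-aminobutyl end would separate the two.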